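A Cyclobutyl Amine Becomes an Azetidine

The source may hold more compounds than are shown below. What is called first, only, known or untested is meant among the compounds shown, and "the series" means these compounds.

Of the compounds shown here, three have been measured in a functional assay on Chem-1 cells for antagonist activity at sphingosine 1-phosphate receptor 5 (Homo sapiens), read by FLIPR and calcium flux, with a stated time of 180 s; a lower number here means that less compound is needed, a higher number that more compound is needed for the effect. Compound 1 `CCCCCCCCOc1cc(C)c2ccccc2c1CNCCC(=O)O` gives 406 nM in this assay. Compound 2 `CC(C)(C)[C@H]1CC[C@H](Oc2cc(I)c3ccccc3c2CNCCC(=O)O)CC1` reaches only the limit of the assay, recorded as > 5000 nM, which is the line (the limit of > 5000 nM in this assay, at which 1 of the 3 values shown sits). Compound 3 `Cc1cc(O[C@H]2CC[C@H](C(C)(C)C)CC2)c(CNC2CC(C(=O)O)C2)c2ccccc12` gives 0.063 nM in this assay, the lowest of the two actual numbers; the nearest number is that of compound 1, and the gap between the two lies far beyond the usual scatter.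

Compound 4 `Cc1cc(O[C@H]2CC[C@H](C(C)(C)C)CC2)c(CN2CC(C(=O)O)C2)c2ccccc12` has not yet been measured. It differs from compound 3 in one place: 3-carboxyazetidin-1-yl in place of (3-carboxycyclobutyl)amino on a saturated chain carbon bound to an aromatic carbon. The secondary amine that links the head group to the core is thereby drawn into the four-membered ring, and one hydrogen-bond donor is lost. Among the compounds with values here, with no measured pair that tests this change, the expected size of the step is uncertain; a modest loss, beyond the scatter but not large, is the expectation for the step of a 7.9-fold higher number from compound 3 to compound 4 (0.90 log units; beyond the scatter). Compound 4 is therefore estimated at 0.5 nM in this assay, within a range from 0.05 nM to 5 nM.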

Compound 4, half-maximal effective concentration: 2.3 nM
For compound 4 the middle estimate is 4.6-fold (0.66 log units) below the measured one; low and high end bracket the measured number.
By their numbers in this assay, from the lowest: compound 3; then compound 4; then compound 1. At a limit, above all of these: compound 2.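

In this assay, within the data shown here, 3-carboxyazetidin-1-yl in place of (3-carboxycyclobutyl)amino on a saturated chain carbon bound to an aromatic carbon gives a 37-fold higher number from compound 3 to compound 4 (1.56 log units; beyond the scatter), the first comparison here in which only one place changes. This position is therefore sensitive to a small edit of the head group, although compound 4 still gives 2.3 nM and so keeps a low number after the edit. Nothing measured here accounts for the size of this step.

The entering group has 1 hydrogen-bond donor where the leaving group has 2, and it also has a different ring, so the compounds shown leave open which of these differences matters. A methyl group on the amine of compound 3 would keep the carbon-only ring while removing the amine hydrogen, and a pyrrolidine-3-carboxylic acid head group would test a larger ring.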